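A few compounds are considered here, and "the series" means these few. Any claim that something is new, unique, unknown or untested is made for them only; others in the source may bear on it.

In an ADME assay on H9c2 cells (Rattus norvegicus) for cytotoxicity, read by resazurin assay, with a stated time of 72 h (a lower number here means that less compound is tolerated, a higher number that more compound is tolerated), compound 1 (`C/C(=N\Nc1nc(CCl)cs1)c1ccc(Cl)c(Cl)c1`) gives > 50000 nM, which is a limit and not a number. The step to compound 4 (`C/C(=N\Nc1nc(-c2ccc(Cl)c(Cl)c2)cs1)c1ccc(Cl)c(Cl)c1`) is 3,4-dichlorophenyl in place of chloromethyl on an aromatic carbon. Compound 2 (`C/C(=N\Nc1nc(-c2ccccn2)cs1)c1ccc(Cl)c(Cl)c1`) gives 10200 nM, and compound 3 (`C/C(=N\Nc1nc(-c2ccncc2)cs1)c1ccc(Cl)c(Cl)c1`) gives 41900 nM. Both carry the same kind of replacement, with pyridin-2-yl or pyridin-4-yl entering. The first replacement gives an at least 4.9-fold lower number from compound 1 to compound 2 (0.69 log units; beyond the scatter), the second at least 1.1-fold lower number from compound 1 to compound 3 (0.07 log units; that floor lies within the scatter), and the two pyridinyl compounds themselves are separated by a 4.1-fold higher number from compound 2 to compound 3 (0.61 log units; beyond the scatter). On these steps, a modest move to a lower number is expected in this assay, though it may not clear the scatter. The expected change is an at least 2.5-fold lower number from compound 1 to compound 4 (0.39 log units; beyond the scatter). For compound 4, the estimated value is 20000 nM, with an expected range of 7000 nM to 50000 nM.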

Compound 4, half-maximal cytotoxic concentration: > 50000 nM
Compound 4 was reported as a limit (the forecaster's own chance of this, stated with the estimate: 25%); middle value at least 2.5-fold (0.39 log units) from the limit.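

In this assay, a large carbon-only aromatic ring is tolerated at this position, next to the ring nitrogen. 3,4-Dichlorophenyl gives an at least 4.9-fold higher number from compound 2 to compound 4 (0.69 log units; beyond the scatter) and an at least 1.1-fold higher number from compound 3 to compound 4 (0.07 log units; that floor lies within the scatter), so the lower number seen with pyridin-2-yl does not extend to every aromatic ring here. The step from compound 1 to compound 4 cannot be read, because both compounds sit at a limit and not at a number: the limit of > 50000 nM in this assay, at which 2 of the 4 values shown sit.

Still open, from the compounds shown here alone, is how far compound 1 and compound 4 lie from that limit. Also open, going by these compounds, is whether an amine, a carboxylic acid or a longer chain at this position would lower the number.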